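The source may hold more compounds than are shown below. What is called first, only, known or untested is meant among the compounds shown, and "the series" means these compounds.

Compound 1 `Cc1cccc(NC(=O)CN2CCC(c3cccc(F)c3)CC2)c1` gives 40% in a functional assay on HEK293 cells for agonist activity at D(4) dopamine receptor (Homo sapiens), read by FLIPR; on this read-out higher numbers stand for larger maximal responses and lower numbers for smaller maximal responses; compound 2 `Cc1cccc(NC(=O)CN2CCC(c3ccc(O)cn3)CC2)c1` gives 83%; compound 3 `Cc1cccc(NC(=O)CN2CCC(c3ccccc3C)CC2)c1` gives 43%.

Compound 3 stands second highest of the three; its nearest neighbour is compound 1, with a number 3 percentage points higher from compound 1 to compound 3 (within the scatter), and its furthest is compound 2, with a number 40 percentage points lower from compound 2 to compound 3 (beyond the scatter). Compound 4 `Cc1cccc(NC(=O)CN2CCC(c3ccccc3C#N)CC2)c1` differs from compound 3 by cyano in place of methyl on an aromatic carbon. Among the compounds with values here, no measured step swaps one substituent on the carbon-only aromatic ring for another such substituent; the only step between two such rings, from compound 1 to compound 3, stayed within the scatter, and the large step from compound 2 to compound 3 involved the pyridine ring instead. Compound 4 is therefore expected to show a number 2 percentage points higher from compound 3 to compound 4 (within the scatter), no step beyond the scatter. The estimate for compound 4 is 45%, between 25% and 70%.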

Compound 4, largest response reached (reported as efficacy), in percent of the reference or control that the assay uses: 71%
For compound 4 the middle estimate is 26 percentage points below the measured one, and the stated range ends below it.
By their numbers in this assay, from the lowest: compounds 1 and 3 (each within the scatter of the next); then compound 4; then compound 2.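

In this assay the substituent ortho to a large group on the carbon-only aromatic ring proves able to move the response, with cyano in place of methyl giving a number 28 percentage points higher from compound 3 to compound 4 (beyond the scatter) and 2-cyanophenyl in place of 3-fluorophenyl giving a number 31 percentage points higher from compound 1 to compound 4 (beyond the scatter) as well. A high response thus no longer belongs to the 5-hydroxypyridin-2-yl compound alone, although a number 12 percentage points lower from compound 2 to compound 4 (beyond the scatter) remains. Nothing available explains why the cyano group has this effect.

As far as these compounds go, it stays open whether a carboxylic acid or a primary amide in place of cyano would act alike. From the compounds shown here alone, whether cyano keeps this effect at another ring position also stays open.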